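Moving from methoxy to hydroxy on a cytotoxic series

The source may hold more compounds than are shown below. What is called first, only, known or untested is meant among the compounds shown, and "the series" means these compounds.

Measured in a functional assay on MCF7 cells (Homo sapiens) for cytotoxicity, read by MTT assay, with a stated time of 72 h (a lower number here means a stronger inhibitor, a higher number a weaker inhibitor), so far
Compound 1 `COc1ccccc1/C=C1\CCC/C(=C\c2ccc(OC)c(OC)c2)C1=O` gives 8000 nM
Compound 2 `COc1cccc(/C=C2\CCC/C(=C\c3ccc(OC)c(OC)c3)C2=O)c1` gives 4600 nM

Compound 2 gives 4600 nM and lies within the scatter of compound 1, which gives 8000 nM here, so the two cannot be ranked. The change leading to compound 3 `COc1ccc(/C=C2\CCC/C(=C\c3cccc(O)c3)C2=O)cc1OC` is hydrogen in place of methyl on an oxygen on an aromatic ring in one place: hydrogen in place of methyl on an oxygen on an aromatic ring, turning 3-methoxyphenyl into 3-hydroxyphenyl. For the measured compounds named here, only one measured step bears on this, and only loosely: a 1.7-fold lower number from compound 1 to compound 2 (0.24 log units; within the scatter) concerns 3-methoxyphenyl in place of 2-methoxyphenyl and leaves the methyl in place. Going by the values given here, no measured compound carries a hydroxy group. No step beyond the scatter is therefore expected in this assay and no firm direction can be given. The expected move is a 1.2-fold lower number from compound 2 to compound 3 (0.06 log units; within the scatter) and would lie within the scatter. Compound 3 is estimated at 4000 nM (expected range 1500 nM to 11000 nM).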

Compound 3, half-maximal inhibitory concentration: 2900 nM
Compound 3: middle estimate off by 1.4-fold (0.14 log units), on the high side; the measured number falls inside the stated range.
By their numbers in this assay, from the lowest: compounds 3, 2 and 1 (each within the scatter of the next, the first and the last beyond it).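

In this assay, hydrogen in place of methyl on the oxygen, turning 3-methoxyphenyl into 3-hydroxyphenyl, gives a 1.6-fold lower number from compound 2 to compound 3 (0.20 log units; within the scatter), so the hydroxy and methoxy groups cannot be ranked at this position. For the compounds shown here, the only step here beyond the scatter is modest, a 2.8-fold lower number from compound 1 to compound 3 (0.44 log units; beyond the scatter), but it changes both the place of the oxygen and the methyl, and compound 2 lies within the scatter of both neighbours, so neither part can be singled out. No measurement given here accounts for these numbers.

Still open, as far as these compounds go, is whether an amine or a carboxylic acid in place of the hydroxy group would give a step beyond the scatter. Also open, from the compounds shown here alone, is whether replacing methyl by hydrogen on the methoxy groups of the other aromatic ring would read the same way.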